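The source may hold more compounds than are shown below. What is called first, only, known or untested is meant among the compounds shown, and "the series" means these compounds.

Of the compounds shown here, three sharing one core have been measured in a functional assay on MCF7 cells (Homo sapiens) for antiproliferative activity, read by CCK-8 assay, with a stated time of 72 h; on this read-out lower numbers stand for stronger inhibition and higher numbers for weaker inhibition. Compound 1 `O=C(Nc1cccc(-c2oc3cc(-c4ccc(F)cc4)ccc3c(=O)c2O)c1)c1ccc(F)cc1F` gives 13500 nM. Compound 2 `O=C(Nc1cccc(-c2oc3cc(-c4ccc(F)cc4)ccc3c(=O)c2O)c1)c1ccc(C(F)(F)F)cc1` gives 32600 nM. Compound 3 `Cc1cc(C(=O)Nc2cccc(-c3oc4cc(-c5ccc(F)cc5)ccc4c(=O)c3O)c2)ccc1F` gives 7710 nM, the lowest of the three numbers, although the step of a 1.8-fold lower number from compound 1 to compound 3 (0.24 log units; within the scatter) stays within the scatter, while a 4.2-fold lower number from compound 2 to compound 3 (0.63 log units; beyond the scatter) lies beyond it. The three differ only in the aryl ring on the carbonyl carbon of the amide, and compound 4 `O=C(Nc1cccc(-c2oc3cc(-c4ccc(F)cc4)ccc3c(=O)c2O)c1)c1cc(F)cc(F)c1` continues that series: 3,5-difluorophenyl in place of 4-fluoro-3-methylphenyl on a carbonyl carbon. Among the compounds with values here, the closest precedent is compound 1, which carries 2,4-difluorophenyl on the same carbonyl carbon, and a 1.8-fold lower number from compound 1 to compound 3 (0.24 log units; within the scatter) shows that exchanging one such ring for another moved the number little. On the other hand, a 2.4-fold higher number from compound 1 to compound 2 (0.38 log units; beyond the scatter) shows that a change on this ring can also raise the number. The expected outcome is a 1.6-fold higher number from compound 3 to compound 4 (0.19 log units; within the scatter). Compound 4 is therefore estimated at 12000 nM, with a range from 5000 nM to 30000 nM.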

Compound 4, half-maximal inhibitory concentration: 2490 nM
Compound 4: the middle estimate sits 4.8-fold (0.68 log units) above what was measured, and the stated range ends above it.
By their numbers in this assay, from the lowest: compound 4; then compounds 3 and 1 (each within the scatter of the next); then compound 2.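

In this assay the exchange of 4-fluoro-3-methylphenyl for 3,5-difluorophenyl on the carbonyl carbon gives a 3.1-fold lower number from compound 3 to compound 4 (0.49 log units; beyond the scatter) and so shows that this ring can bring the number clearly below the level of compound 1 and compound 3. Set against the other two rings, the new ring gives a 5.4-fold lower number from compound 1 to compound 4 (0.73 log units; beyond the scatter) and a 13-fold lower number from compound 2 to compound 4 (1.12 log units; beyond the scatter) as well, and the first of these shows that two difluorophenyl rings, differing only in where their fluorines sit, are not interchangeable here. Nothing available explains why this ring gives the lowest number.

Going by these compounds, it stays open whether a methoxy group, a nitrile or an amine on this ring would lower the number further. On these data alone, whether the order of these four compounds holds in other cell lines also remains unknown.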